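Spiro series: amide end swapped from hydroxyethylamino to ethylpiperidinyl

This account rests on a few compounds, and the source may have more. Where it says the series, first, only, none or still open, it means among the compounds named here.

Measured so far in an assay on HEK293 cells for displacement of a labelled ligand from NPC1-like intracellular cholesterol transporter 1 (Homo sapiens); on this read-out lower numbers stand for stronger inhibition and higher numbers for weaker inhibition:
compound 1, `CC(C)(C)c1ccc(C(=O)N2CCC3(CC2)C(=O)N(CC(=O)NCCO)CN3c2ccccc2)cc1`, 1000 nM
compound 2, `O=C(CN1CN(c2ccccc2)C2(CCN(C(=O)c3ccc(C4CCCCC4)cc3)CC2)C1=O)NCCO`, 2000 nM
compound 3, `CCc1nn(CC)c(C2CCN(C(=O)CN3CN(c4ccccc4)C4(CCN(C(=O)c5ccc(C(C)(C)C)cc5)CC4)C3=O)CC2)c1CC`, 4600 nM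

Compound 2 sits second highest of the three numbers. Its nearest neighbour is compound 1, with a 2.0-fold higher number from compound 1 to compound 2 (0.30 log units; within the scatter), a step inside the scatter, so the two cannot be ordered. The furthest is compound 3, whose number is beyond the scatter from that of compound 2.

The next compound, compound 4, `CCC1CCCN(C(=O)CN2CN(c3ccccc3)C3(CCN(C(=O)c4ccc(C5CCCCC5)cc4)CC3)C2=O)C1`, keeps the cyclohexyl end of compound 2 and changes the other end: 3-ethylpiperidin-1-yl in place of (2-hydroxyethyl)amino on a carbonyl carbon.

Within the data shown here, no measured step bears on this change directly. Among the measured compounds shown here, the only measured step, from compound 1 to compound 2, touches the aromatic substituent, not the amide end, and is within the scatter. The pair compound 1 and compound 3 is the closest guide: both carry tert-butyl and differ only at the amide end, where a nitrogen-linked six-membered ring replaces the (2-hydroxyethyl)amino group; compound 1 gives 1000 nM and compound 3 gives 4600 nM. On that basis a weaker number is expected for compound 4, with a step of roughly a 2.3-fold higher number from compound 2 to compound 4 (0.35 log units; beyond the scatter) in this assay. The estimate for compound 4 is 4500 nM, with a range from 1500 nM to 12000 nM.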

Compound 4, half-maximal inhibitory concentration: 2600 nM
Compound 4: the middle estimate sits 1.7-fold (0.24 log units) above what was measured; the measured number falls inside the stated range.
By their numbers in this assay, from the lowest: compounds 1, 2, 4 and 3 (each within the scatter of the next, the first and the last beyond it).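

In this assay, replacing (2-hydroxyethyl)amino with 3-ethylpiperidin-1-yl on a carbonyl carbon of the cyclohexyl compound gives a 1.3-fold higher number from compound 2 to compound 4 (0.11 log units; within the scatter), so compound 2 and compound 4 cannot be ordered. At this position, with cyclohexyl on the other end, a ring-bearing group with 0 hydrogen-bond donors and 0 hydrogen-bond acceptors can therefore stand in place of a chain with 2 hydrogen-bond donors and 1 hydrogen-bond acceptor without a readable difference, whereas the tert-butyl compounds with different amide ends, compound 1 at 1000 nM and compound 3 at 4600 nM, lie beyond the scatter of each other. Nothing available gives a reason for this outcome.

Open, from the compounds shown here alone, is whether 3-ethylpiperidin-1-yl gives a comparable number when paired with tert-butyl, which would show whether the outcome at this position depends on the group at the other end. Also open, going by these compounds, is how the number responds when the ethyl of 3-ethylpiperidin-1-yl is replaced by a carboxylic acid, a primary amine or a longer alkyl chain.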